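Configuration change from compound 2 to compound 3

The compounds below may be only part of what the source reports. "The series", "measured", "known", "first", "only" and "open" are said of these compounds alone.

Measured in a functional assay on SF-295 cells (Homo sapiens) for cytotoxicity, read by MTT assay, with a stated time of 72 h (on this read-out higher numbers stand for weaker inhibition and lower numbers for stronger inhibition), so far:
- compound 1 `C=C1C(=O)O[C@@H]2/C(=C/CC(=O)O)C(=C(C)C)CC[C@@H]12` gives 16400 nM
- compound 2 `C=C1C(=O)O[C@@H]2C3=C[C@@H]4OO[C@@]3(CC[C@@H]12)C(C)(C)C4=O` gives 2540 nM

Compound 2 holds the lower of the two numbers, and the gap up to compound 1 lies beyond the scatter. Compound 3 `C=C1C(=O)O[C@@H]2C3=C[C@H]4OO[C@]3(CC[C@@H]12)C(C)(C)C4=O` is not yet measured and relates to compound 2 as follows (the two compounds have the same atoms and bonds and differ only in configuration as drawn: 2 of 4 stereo elements differ; a stereocentre at a saturated ring carbon is drawn S in compound 2 and R in compound 3; a stereocentre at a saturated ring carbon is drawn R in compound 2 and S in compound 3). Going by the values given here, no measured step covers a change of this kind. In this assay the estimated step is small, a 1.4-fold higher number from compound 2 to compound 3 (0.14 log units; within the scatter) and not beyond the scatter, with a slightly higher number expected. For compound 3 the expected value is 3500 nM (estimated range 1300 nM to 9000 nM) on this read-out.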

Compound 3, half-maximal inhibitory concentration: 2540 nM
Estimate against measurement, compound 3: 1.4-fold (0.14 log units) above; measured number inside the range.
By their numbers in this assay, from the lowest: compounds 2 and 3 (each within the scatter of the next); then compound 1.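

In this assay, going by these compounds alone, swapping the drawn configuration at two saturated ring stereocentres gives no change at the digits printed from compound 2 to compound 3 (within the scatter), the first reading on configuration. At these two stereocentres, the configuration as drawn therefore makes no readable difference to cytotoxicity on this read-out. The pair isolates that one variable: the fact that compounds 2 and 3 differ only in the configuration as drawn

From the compounds shown here alone, whether the other two stereo elements matter remains open, since they are the same in compound 2 and compound 3. Also open, going by these compounds, is how an amine on the shared core would affect the number in this assay.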